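Swapping the hydroxamate amide for an ester-bearing amide

The source may report more compounds than this note shows. Statements on the series, on what has been measured and on what is new or still open speak of the compounds shown alone.

Two compounds of this series have been examined in an assay on isolated protein for inhibition of Apoptosis regulator Bcl-2 (Homo sapiens), read by fluorescence polarization, with stated times of 5 min and 10 min; a higher number here means a weaker inhibitor, a lower number a stronger inhibitor. Compound 1 `CC(C)=CCCC1=CC[C@H](C(=O)Nc2ccc(C(=O)O)cc2)[C@@H](c2ccccc2)C1` carries an anilide that bears a carboxylic acid, and in this assay compound 1 returns only a limit, > 23000 nM. Compound 2 `CC(C)=CCCC1=CC[C@@H](C(=O)N(C)O)[C@H](c2ccccc2)C1` is the hydroxy(methyl)carbamoyl analogue; in this assay compound 2 gives 2300 nM, the only result reported as a number in this set. The other result, that of compound 1, is the limit of > 23000 nM in this assay, at which 1 of the 2 values shown sits. For the measured compounds named here, no pair of measured compounds differs in a single place, so no measured step is available to anchor the effect of changing the group on the carbonyl carbon.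

Compound 3 `COC(=O)CCNC(=O)[C@@H]1CC=C(CCC=C(C)C)C[C@H]1c1ccccc1` keeps the core of compound 2 and differs there only: (2-(methoxycarbonyl)ethyl)amino in place of hydroxy(methyl)amino on a carbonyl carbon. The small hydroxy-bearing amine gives way to a longer chain ending in a methoxycarbonyl group. Going by the values given here, with compound 1 at its limit and compound 2 as the sole number, the account expects the step from compound 2 to compound 3 to be a loss beyond the scatter, a 5.2-fold higher number from compound 2 to compound 3 (0.72 log units; beyond the scatter). Compound 3 is therefore estimated at 12000 nM in this assay, within a range from 4000 nM to 35000 nM, with a real chance that only a limit is reported.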

Compound 3, inhibition constant: > 23000 nM
Compound 3 was reported as a limit; the forecaster's own chance of this, stated with the estimate: 40%; at least 1.9-fold (0.28 log units) between middle value and limit.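

The carbonyl carbon now gives the series its first measured step: in this assay, replacing hydroxy(methyl)amino with (2-(methoxycarbonyl)ethyl)amino gives an at least 10-fold higher number from compound 2 to compound 3 (1.00 log units; beyond the scatter). As far as these compounds go, compound 3 returns only a limit, so this step marks a minimum and its full size stays unknown. The group on this carbonyl carbon therefore matters to the read-out, and only compound 2, with hydroxy(methyl)amino, has a result reported as a number, while the other two results stand at one limit: the limit of > 23000 nM in this assay, at which 2 of the 3 values shown sit.

The change swaps the whole group at once, so the compounds shown do not separate the longer chain and its methoxycarbonyl end from the departure of the hydroxy(methyl)amino group itself. A plain methylamino group would test what the hydroxy group contributes, while the same chain ending in a carboxylic acid, or a shorter chain ending in methoxycarbonyl, would show whether the end of the chain or its length weighs more at this position.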